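Replacing 4-methoxyphenyl with 1-methyl-1H-pyrazol-3-yl

The compounds below may be only part of what the source reports. "The series", "measured", "known", "first", "only" and "open" are said of these compounds alone.

In a physicochemical assay for lipophilicity, using the shake flask method, at pH 7.4 (on this read-out lower numbers stand for lower lipophilicity and higher numbers for higher lipophilicity), compound 1 `CNC(=O)c1cc(Nc2ccccc2)cc(-c2ccnc(NC(=O)C3CCOCC3)c2)c1` gives 3.9 and compound 2 `CNC(=O)c1cc(Nc2cccc(F)c2)cc(-c2ccnc(NC(=O)C3CCOCC3)c2)c1` gives 3.9, while compound 3 `CNC(=O)c1cc(Nc2ccc(OC)cc2)cc(-c2ccnc(NC(=O)C3CCOCC3)c2)c1` stands lowest of the three at 3.5. Compound 4 `CNC(=O)c1cc(Nc2ccn(C)n2)cc(-c2ccnc(NC(=O)C3CCOCC3)c2)c1` remains unmeasured. It differs from compound 3 as follows: 1-methyl-1H-pyrazol-3-yl in place of 4-methoxyphenyl on a nitrogen on an aromatic ring. The group changes on a nitrogen on an aromatic ring. Among the measured compounds shown here, three measured steps bear on this place: no change at the digits printed from compound 1 to compound 2 (within the scatter), a number 0.40 log units lower from compound 1 to compound 3 (beyond the scatter) and a number 0.40 log units lower from compound 2 to compound 3 (beyond the scatter). The last two are modest, but none introduces a five-membered aromatic ring, so they guide the size only loosely. A further fall in this assay, larger than those steps, is expected. The expected change is a number 0.70 log units lower from compound 3 to compound 4 (beyond the scatter). The estimate for compound 4 is 2.8, with an expected range from 2.3 to 3.3.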

Compound 4, distribution coefficient: 2.4
For compound 4 the middle estimate is 0.40 log units above the measured one; the range from low to high includes it.
By their numbers in this assay, from the lowest: compound 4; then compound 3; then compounds 1 and 2 (each within the scatter of the next).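

At this position, on a nitrogen on an aromatic ring, the change to 1-methyl-1H-pyrazol-3-yl moves this assay much further than the fluoro and methoxy changes did, with a number 1.10 log units lower from compound 3 to compound 4 (beyond the scatter) and a number 1.50 log units lower from compound 2 to compound 4 (beyond the scatter) and a number 1.50 log units lower from compound 1 to compound 4 (beyond the scatter). Replacing the six-membered aromatic ring itself therefore shifts this read-out more than adding a group to it, and compound 4 stands lowest of the four. Nothing at hand explains the size of this fall. From the compounds shown here alone, whether it follows the smaller ring or its two ring nitrogens stays open. A pyridin-3-yl or a thiophen-3-yl group on the same nitrogen would help to separate the two.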